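From thiophen-2-yl to pyridin-4-yl on the shared core

The compounds below may be only part of what the source reports. "The series", "measured", "known", "first", "only" and "open" are said of these compounds alone.

In a functional assay on HL-60 cells (Homo sapiens) for cytotoxicity, read by ELISA, with a stated time of 2 days (on this read-out lower numbers stand for stronger inhibition and higher numbers for weaker inhibition), compound 3 `Oc1cccc(-c2cc(-c3ccccc3)nc(-c3cccs3)c2)c1` gives 18900 nM. Compound 1 `Oc1cccc(-c2cc(-c3ccccc3)cc(-c3cccc(O)c3)n2)c1` gives 16400 nM, which lies within the scatter of the number for compound 3. Compound 2 `Oc1ccc(-c2cc(-c3ccccc3)cc(-c3ccccc3)n2)cc1` gives 1400 nM, and the gap between this number and that of compound 3 lies beyond the scatter, with compound 3 on the weaker side.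

The next compound to be measured is compound 4 `Oc1cccc(-c2cc(-c3ccccc3)nc(-c3ccncc3)c2)c1`, which has pyridin-4-yl in place of thiophen-2-yl on an aromatic carbon, next to the ring nitrogen: pyridin-4-yl in place of thiophen-2-yl on an aromatic carbon. Within the data shown here, no measured pair isolates this exchange, so the expectation has little direct support. Compound 1 at 16400 nM and compound 3 at 18900 nM differ in structure yet remain within the scatter, which gives a weak reason to expect no large move. The estimated step is a 1.4-fold lower number from compound 3 to compound 4 (0.13 log units; within the scatter), a small expected move towards a lower number that stays within the scatter. For compound 4 the expected value is 14000 nM, with an estimated range from 4500 nM to 40000 nM.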

Compound 4, half-maximal inhibitory concentration: 12700 nM
Beside the measured number, compound 4's estimate is 1.1-fold (0.04 log units) above it, and the stated range covers the measured number.
By their numbers in this assay, from the lowest: compound 2; then compounds 4, 1 and 3 (each within the scatter of the next).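

In this assay, among these compounds, a 1.5-fold lower number from compound 3 to compound 4 (0.17 log units; within the scatter) gives the first pair that isolates this position, the aromatic carbon next to the ring nitrogen, with pyridin-4-yl in place of thiophen-2-yl. The step lies within the scatter, so this read-out does not tell the five-membered aromatic ring from the six-membered one here, at least on a core that also carries the 3-hydroxyphenyl and phenyl groups. Nothing available gives a reason for this result.

Open, as far as these compounds go, is whether any group at this position moves the number beyond the scatter, for example an amine, a carboxylic acid or a longer alkyl chain in place of the aromatic ring. Also open, from the compounds shown here alone, is whether the same exchange stays this small on a core without the 3-hydroxyphenyl group.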